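The source may report more compounds than this note shows. Statements on the series, on what has been measured and on what is new or still open speak of the compounds shown alone.

Measured compounds:
- compound 1 `Cc1ccc(/C=C(\C(=O)c2ccc([N+](=O)[O-])cc2)S(=O)(=O)Cc2ccc(Cl)cc2)s1`: 25000 nM
- compound 2 `CSc1ccc(/C=C(\C(=O)c2ccc(Cl)cc2)S(=O)(=O)Cc2ccc(Cl)cc2)cc1`: 10000 nM

Both were tested in a functional assay on DU-145 cells (Homo sapiens) for inhibition, read by trypan blue exclusion, with a stated time of 96 h; on this read-out lower numbers stand for stronger inhibition of growth and higher numbers for weaker inhibition of growth. Compound 2, at 10000 nM, holds the lower of the two numbers, and the gap up to compound 1 lies beyond the scatter.

Compound 3 `Cc1ccc(/C=C(\C(=O)c2ccc(Cl)cc2)S(=O)(=O)Cc2ccc(Cl)cc2)s1` keeps the rest of compound 2 but has 5-methylthiophen-2-yl in place of 4-(methylsulfanyl)phenyl on a double-bonded chain carbon bound to a double-bonded chain carbon. Among the compounds with values here, the only measured compound with that group is compound 1 at 25000 nM, and it also differs from compound 3 elsewhere, so it is a loose guide.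

In this assay, a small move towards a higher number is expected, and the estimated 1.5-fold higher number from compound 2 to compound 3 (0.18 log units; within the scatter) should not go beyond the scatter. For compound 3 the estimated value is 15000 nM, with an expected range of 6000 nM to 40000 nM.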

Compound 3, concentration for 50% growth inhibition: 1000 nM
Compound 3: the middle estimate sits 15-fold (1.18 log units) above what was measured; measured number outside the range, below it.
By their numbers in this assay, from the lowest: compound 3; then compound 2; then compound 1.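

In this assay the swap to 5-methylthiophen-2-yl on a double-bonded chain carbon bound to a double-bonded chain carbon gives a 10-fold lower number from compound 2 to compound 3 (1.00 log units; beyond the scatter) with the rest of the structure unchanged, so this position responds strongly to the group it carries. With 5-methylthiophen-2-yl held fixed, chloro in place of nitro on an aromatic carbon gives a 25-fold lower number from compound 1 to compound 3 (1.40 log units; beyond the scatter) and the high number of compound 1 therefore cannot be read as a property of 5-methylthiophen-2-yl alone. Nothing available here explains either step.

The compounds shown leave open whether the gain belongs to the five-membered ring or to its methyl, which a plain thiophen-2-yl group would separate. Going by these compounds, it also remains open how an amine or a carboxylic acid in place of that methyl would read.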